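The source may report more compounds than this note shows. Statements on the series, on what has been measured and on what is new or still open speak of the compounds shown alone.

Measured so far:

Compound 1 `CC(C)(C)C1=NN(c2cccc(F)c2)C(c2ccc(O)cc2)C1`: 2200 nM
Compound 2 `CC(C)(C)C1=NN(c2ccc(Cl)cc2)C(c2ccc(Br)cc2)C1`: "not determined" (no result reported)
Compound 3 `CC(C)(C)C1=NN(c2ccc(O)cc2)C(c2ccc(Cl)cc2)C1`: "not determined" (no result reported)

Three compounds share the same core and were tested in an assay on isolated protein for inhibition of protein kinase C zeta type (Homo sapiens), with a stated time of 4 min; a lower number here means a stronger inhibitor, a higher number a weaker inhibitor. Only compound 1 has a number; compound 2 and compound 3 have no reported result, so compound 2 stands nowhere on the scale yet and offers no measured anchor of its own.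

Compound 4 `CC(C)(C)C1=NN(c2ccc(Cl)cc2)C(c2ccc(O)c(Cl)c2)C1` differs from compound 2 in one place: 3-chloro-4-hydroxyphenyl in place of 4-bromophenyl on a saturated ring carbon. In words, a 3-chloro-4-hydroxyphenyl takes the place of a 4-bromophenyl on a saturated ring carbon. Among the compounds with values here, no pair of measured compounds shows the size of such a step in this assay, so its direction is open. Within the data shown here, the only hint is that compound 1, which also carries a hydroxyphenyl on that saturated ring carbon, gives 2200 nM in this assay; the new compound is expected to fall in the same broad region. Compound 4 is therefore estimated at about 1500 nM in this assay, with a likely range from 300 nM to 8000 nM.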

Compound 4, half-maximal inhibitory concentration: 700 nM
Compound 4: middle estimate off by 2.1-fold (0.33 log units), on the high side; the range from low to high includes it.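

Compound 4, at 700 nM, differs in one place only from compound 2, for which no number is shown, so no new step can be read. On these data alone, the effect of replacing 4-bromophenyl with 3-chloro-4-hydroxyphenyl in this assay stays open. No supporting data bear on this result.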